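The compounds below may be only part of what the source reports. "The series", "measured", "known", "first", "only" and "open" are said of these compounds alone.

Three compounds sharing one core have been examined in an ADME assay on microsomes from liver (Homo sapiens) for metabolic stability, tested at 2.5 uM (on this read-out higher numbers stand for fast clearance and lower numbers for slow clearance), and they differ only in the aryl group attached to a sulfonyl sulfur. Compound 1 `COc1ccc(-c2c(S(=O)(=O)c3ccc(OC)cc3)cnc3cc(F)ccc23)cc1` carries a 4-methoxyphenyl there and gives 1.18 mL/min. Compound 2 `COc1ccc(-c2c(S(=O)(=O)c3ccc(F)c(F)c3)cnc3cc(F)ccc23)cc1` carries a 3,4-difluorophenyl and gives 1.1 mL/min. Compound 3 `COc1ccc(-c2c(S(=O)(=O)c3cc(F)cc(F)c3)cnc3cc(F)ccc23)cc1` carries a 3,5-difluorophenyl and gives 1.51 mL/min. The three numbers sit close together: the step of a 1.1-fold lower number from compound 1 to compound 2 (0.03 log units; within the scatter), the step of a 1.3-fold higher number from compound 1 to compound 3 (0.11 log units; within the scatter) and the step of a 1.4-fold higher number from compound 2 to compound 3 (0.14 log units; within the scatter) all lie within the usual scatter, so on this read-out compound 3 stands alongside compound 1 and compound 2 rather than apart from them.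

Compound 4 `COc1ccc(-c2c(S(=O)(=O)c3ccc(F)c(Cl)c3)cnc3cc(F)ccc23)cc1` continues this series with a single change: 3-chloro-4-fluorophenyl in place of 3,5-difluorophenyl on a sulfonyl sulfur. For the measured compounds named here, the steps that bear on it are the three already seen, in which swapping one aryl group on the sulfonyl sulfur for another, whether methoxy-bearing or fluorine-bearing, moved the number by no more than the scatter. On that basis a step from compound 3 to compound 4 of no more than the scatter is expected, with no clear direction.

The number expected for compound 4 is therefore 1.3 mL/min, with a range from 0.75 mL/min to 2.3 mL/min, corresponding to an estimated step of a 1.2-fold lower number from compound 3 to compound 4 (0.07 log units; within the scatter).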

Compound 4, intrinsic clearance in a liver preparation (reported as CLH), per the amount of preparation that the assay uses: 1.08 mL/min
Beside the measured number, compound 4's estimate is 1.2-fold (0.08 log units) above it; measured number inside the range.
By their numbers in this assay, from the lowest: compounds 4, 2, 1 and 3 (each within the scatter of the next).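

In this assay, the swap of chloro in place of fluoro on an aromatic carbon gives the closest comparison so far (a 1.0-fold lower number from compound 2 to compound 4 (0.01 log units; within the scatter)), and it shows that this one-atom exchange on the aryl group leaves the number within the usual scatter. The two wider exchanges on the sulfonyl sulfur, seen in the steps (a 1.4-fold lower number from compound 3 to compound 4 (0.15 log units; within the scatter)) and (a 1.1-fold lower number from compound 1 to compound 4 (0.04 log units; within the scatter)), also stay within the scatter. Chlorine is new at this place, and with it the 3-chloro-4-fluorophenyl group joins the three aryl groups seen earlier, so all four read alike in this assay. Nothing shown here offers a measured explanation for this sameness.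

Going by these compounds, all four aryl groups are phenyl rings bearing only fluoro, chloro or methoxy, so it remains open how far this tolerance on the sulfonyl sulfur extends. An aryl group carrying an amine or a carboxylic acid, or a longer chain on the ring, could still move the number beyond the scatter, and the four compounds cannot tell whether it would.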